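The source may report more compounds than this note shows. Statements on the series, on what has been measured and on what is new or still open speak of the compounds shown alone.

In a functional assay on PBMC cells (Homo sapiens) for inhibition, read by HTRF, with stated times of 15 min and 24 h (a lower number here means a stronger inhibitor, a higher number a weaker inhibitor), compound 2 `O=C(Nc1ccc2c(c1)B(O)OC2)c1cc(C(F)(F)F)ccc1F` reads > 100000 nM, which is a limit of the assay and not a number. Compound 3 `O=C(Nc1ccc2c(c1)B(O)OC2)c1cc(C(F)(F)F)ccc1C(F)(F)F` differs from it at one place: trifluoromethyl in place of fluoro on an aromatic carbon, with trifluoromethyl in place of fluoro on an aromatic carbon. Compound 1 `O=C(Nc1ccc2c(c1)B(O)OC2)c1cc(F)ccc1C(F)(F)F`, which has trifluoromethyl in that place too, gives 11000 nM. On that basis, compound 3 is expected to inhibit more strongly than compound 2 in this assay, by a margin beyond the scatter. The estimated change is an at least 5.0-fold lower number from compound 2 to compound 3 (0.69 log units; beyond the scatter). For compound 3 the expected value is 20000 nM, within an estimated range of 5000 nM to 100000 nM.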

Compound 3, half-maximal inhibitory concentration: 2000 nM
Beside the measured number, compound 3's estimate is 10-fold (1.00 log units) above it; the whole stated range lies above it.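

In this assay, trifluoromethyl in place of fluoro at this position, ortho to a large group, gives an at least 50-fold lower number from compound 2 to compound 3 (1.69 log units; beyond the scatter), a large step. The same exchange elsewhere on the ring gives a 5.5-fold lower number from compound 1 to compound 3 (0.74 log units; beyond the scatter), a modest one, so compound 3, with both trifluoromethyl groups, reads a lower number than either compound with one fluoro. The first step rests on a limit for compound 2, not a number: the limit of > 100000 nM in this assay, at which 1 of the 3 values shown sits. As far as these compounds go, whether a chloro, methoxy or nitrile group at this position would act like trifluoromethyl stays open, as does the effect of an amine there.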